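Series notes: amide swap on the ring amine of compound 2

A few compounds are considered here, and "the series" means these few. Any claim that something is new, unique, unknown or untested is made for them only; others in the source may bear on it.

Three compounds of this series have a number in a physicochemical assay for lipophilicity, using the shake flask method, measured as octanol-water partition, at pH 7.4; a higher number here means a more lipophilic compound, a lower number a more polar compound. Compound 1 `COc1cc(C(=O)N2CCCC2)ccc1-c1ccnc2[nH]c(C3CCOCC3)cc12` gives 3. Compound 3 `COc1cc(F)ccc1-c1ccnc2[nH]c(C3CCN(C(C)=O)CC3)cc12` gives 3.4. Compound 2 `CC(=O)N1CCC(c2cc3c(-c4ccc(=O)n(C(C)C)c4)ccnc3[nH]2)CC1` gives 2.1, the lowest of the three: compound 1 stands a step above it that is beyond the scatter, and compound 3 stands further above it, also beyond the scatter. None of these three pairs differs in one place only, so the gaps between them are read as what the two values show and nothing more.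

Compound 4 `CNC(=O)CN1CCC(c2cc3c(-c4ccc(=O)n(C(C)C)c4)ccnc3[nH]2)CC1` is not yet measured. It differs from compound 2 in one place, on an amine nitrogen in a ring of a six-membered non-aromatic ring with one nitrogen: (methylcarbamoyl)methyl in place of acetyl on an amine nitrogen in a ring. The acetyl leaves and the (methylcarbamoyl)methyl enters, a group that brings a hydrogen-bond donor where the acetyl had none.

Among the compounds with values here, no measured pair in this set shows this change, so the size of the step is taken as an expectation only. For compound 4 in this assay a modest move downward from compound 2 is expected, a step of about a number 0.60 log units lower from compound 2 to compound 4 (beyond the scatter), somewhat beyond the scatter but not large. Compound 4 is therefore estimated at 1.5, with a range from 0.9 to 2.1.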

Compound 4, distribution coefficient: 2.2
Compound 4: middle estimate off by 0.70 log units, on the low side; measured number above the stated range.
By their numbers in this assay, from the lowest: compounds 2 and 4 (each within the scatter of the next); then compound 1; then compound 3.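

In this assay, within the data shown here, replacing acetyl with (methylcarbamoyl)methyl on the amine nitrogen of the six-membered ring gives a number 0.10 log units higher from compound 2 to compound 4 (within the scatter) and is the first change that can be read in one place. At this position on the core of compound 2, the entering group's hydrogen-bond donor and larger heavy-atom count therefore come with no step beyond the scatter, so this exchange leaves the number in this assay effectively unresolved from that of the acetyl amide. The data shown give no explanation for this result.

Among these compounds, it remains open whether this holds for other substituents on the same nitrogen, such as a free amine, a carboxylic acid or a longer chain ending in the same methyl amide, since one pair fixes only this single exchange. Going by these compounds, it is also open whether the same exchange would give a comparable step on the core of compound 3, which carries the acetyl at this nitrogen but differs from compound 2 in its other aromatic group.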